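The compounds below may be only part of what the source reports. "The series", "measured", "known", "first", "only" and "open" are said of these compounds alone.

Measured so far in a functional assay on HEK293 cells (Homo sapiens) for cytotoxicity; on this read-out higher numbers stand for lower toxicity in this test and lower numbers for higher toxicity in this test:
- compound 1 `COc1ccc([C@H]2CC(=O)N(c3cccc([S+](C)[O-])c3)C2)cc1OC1CCCC1`: > 10000 nM, a limit
- compound 2 `COc1ccc(OC)c(S(=O)(=O)Nc2cccc(N3C[C@@H](c4ccc(OC)c(OC5CCCC5)c4)CC3=O)c2)c1`: 7590 nM
- compound 3 `COc1ccc([C@H]2CC(=O)N(c3cccc(NS(=O)(=O)c4c(F)cccc4F)c3)C2)cc1OC1CCCC1`: > 10000 nM, a limit

Compound 3 has no number, only a limit. That places compound 3 on (the limit of > 10000 nM in this assay, at which 2 of the 3 values shown sit).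

Compound 4 `COc1ccc([C@H]2CC(=O)N(c3cccc(NS(=O)(=O)c4c(Br)nn(C)c4Cl)c3)C2)cc1OC1CCCC1` carries 3-bromo-5-chloro-1-methyl-1H-pyrazol-4-yl in place of 2,6-difluorophenyl on a sulfonyl sulfur.

The closest measured change is at the same place: an at least 1.3-fold higher number from compound 2 to compound 3 (0.11 log units; that floor lies within the scatter). The other measured step, a step that the two limits leave unreadable from compound 1 to compound 3, gives no size. Neither shows a swap on the sulfonyl sulfur moving this assay beyond the scatter, though the limits hide how large such a move could be. No clear direction is therefore expected, and the expected step is small: a number no higher from compound 3 to compound 4 (the limit leaves the size open). A result reported only as a limit is also expected to be likely for compound 4. The estimate for compound 4 is 10000 nM. The expected range for compound 4 runs from 5000 nM to 20000 nM.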

Compound 4, half-maximal cytotoxic concentration: > 10000 nM
Compound 4: only a limit was reported; the forecaster's own chance of this, stated with the estimate: 65%; the middle value sits exactly at the limit.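

In this assay, compound 4 gives > 10000 nM, a limit. Putting 3-bromo-5-chloro-1-methyl-1H-pyrazol-4-yl in place of 2,5-dimethoxyphenyl on the sulfonyl sulfur gives an at least 1.3-fold higher number from compound 2 to compound 4 (0.11 log units; that floor lies within the scatter), while the steps to compound 4 from compound 1 and compound 3 cannot be read, as both ends are limits. A five-membered aromatic ring with 2 hetero atoms on the sulfonyl sulfur therefore leaves the result where the six-membered aromatic ring of carbon only in compound 3 left it, at the shared limit: the limit of > 10000 nM in this assay, at which 3 of the 4 values shown sit.

With most values at this limit, the compounds shown give no size for any swap on the sulfonyl sulfur. On these data alone, whether an amine or a carboxylic acid on a group at this sulfur would bring a measurable number into this assay stays open.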